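Replacing 2-methoxyphenyl with benzyl at the assay limit

A few compounds are considered here, and "the series" means these few. Any claim that something is new, unique, unknown or untested is made for them only; others in the source may bear on it.

- Compound 1 (`COc1ccccc1NC(=S)N/N=C/c1ccc2ccccc2n1`) gives > 100000 nM (a limit)
- Compound 2 (`COc1ccc(C)cc1NC(=S)N/N=C/c1ccc2ccccc2n1`) gives > 100000 nM (a limit)

In a functional assay on HT-29 cells (Homo sapiens) for antiproliferative activity, read by sulforhodamine B assay, with a stated time of 72 h (on this read-out lower numbers stand for stronger inhibition and higher numbers for weaker inhibition), compound 1 stands at a limit of the assay, not a number (> 100000 nM). Compound 2 stands at a limit too (> 100000 nM). Among the compounds with values here, the one measured step (a step that the two limits leave unreadable from compound 1 to compound 2) therefore offers no usable size, and both values share one ceiling (the limit of > 100000 nM in this assay, at which 2 of the 2 values shown sit). Compound 3 (`S=C(NCc1ccccc1)N/N=C/c1ccc2ccccc2n1`) has benzyl in place of 2-methoxyphenyl on an amide-type nitrogen. Weak activity is expected in this assay, and any readable step should point toward stronger inhibition. The expected step is modest (an at least 1.6-fold lower number from compound 1 to compound 3 (0.22 log units; that floor lies within the scatter)). The estimate for compound 3 is 60000 nM (range 8000 nM to 100000 nM).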

Compound 3, half-maximal inhibitory concentration: 75700 nM
Compound 3: the middle estimate sits 1.3-fold (0.10 log units) below what was measured; the range from low to high includes it.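

Within the data shown here, with benzyl in place of 2-methoxyphenyl on the amide-type nitrogen, compound 3 gives the first readable number in this assay (75700 nM). The change reads as an at least 1.3-fold lower number from compound 1 to compound 3 (0.12 log units; that floor lies within the scatter), so it does not establish a real gain in activity. As far as these compounds go, the true size of the step stays unknown because compound 1 sits at a limit of the assay: the limit of > 100000 nM in this assay, at which 2 of the 3 values shown sit.

This single swap removes the methoxy group and changes the attachment to the ring together, so their separate contributions stay unresolved. From the compounds shown here alone, whether a longer chain such as phenethyl, or an aminoalkyl group, on this nitrogen would lower the number further also remains open.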